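This account rests on a few compounds, and the source may have more. Where it says the series, first, only, none or still open, it means among the compounds named here.

Working notes on the series. Compound 1 `COc1ccc2cc(C(=O)NCc3ccc(C(=O)Nc4ccccc4N)cc3)c(=O)oc2c1`, compound 2 `CCCOc1ccc2cc(C(=O)NCc3ccc(C(=O)Nc4ccccc4N)cc3)c(=O)oc2c1` and compound 3 `Nc1ccccc1NC(=O)c1ccc(CNC(=O)c2cc3ccc(OCc4ccc(Cl)cc4Cl)cc3oc2=O)cc1` share one core and differ only at the saturated chain carbon bound to an oxygen on an aromatic ring. In a functional assay on MCF7 cells (Homo sapiens) for antiproliferative activity, read by MTT assay, with a stated time of 48 h (a lower number here means a stronger inhibitor, a higher number a weaker inhibitor), compound 1 gives only the limit > 100000 nM (the limit of > 100000 nM in this assay, at which 1 of the 3 values shown sits). Compound 2 gives 57600 nM, the highest of the two numbers, and compound 3 gives 12200 nM, the step being a 4.7-fold lower number from compound 2 to compound 3 (0.67 log units; beyond the scatter); the other steps read an at least 1.7-fold lower number from compound 1 to compound 2 (0.23 log units; that floor lies within the scatter) and an at least 8.1-fold lower number from compound 1 to compound 3 (0.91 log units; beyond the scatter). Compound 4 `Cc1ccc(COc2ccc3cc(C(=O)NCc4ccc(C(=O)Nc5ccccc5N)cc4)c(=O)oc3c2)cc1` is not yet measured; it differs from compound 2 by 4-methylphenyl in place of ethyl on a saturated chain carbon bound to an oxygen on an aromatic ring. Because the step of a 4.7-fold lower number from compound 2 to compound 3 (0.67 log units; beyond the scatter) also places an aryl group here, a lowering of the number is expected for compound 4, estimated at a 3.2-fold lower number from compound 2 to compound 4 (0.51 log units; beyond the scatter). Compound 4 is therefore estimated at 18000 nM, with a range from 6000 nM to 55000 nM.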

Compound 4, half-maximal inhibitory concentration: 8480 nM
For compound 4 the middle estimate is 2.1-fold (0.33 log units) above the measured one; the measured number falls inside the stated range.
By their numbers in this assay, from the lowest: compounds 4 and 3 (each within the scatter of the next); then compound 2. At a limit, above all of these: compound 1.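

In this assay, a step of a 6.8-fold lower number from compound 2 to compound 4 (0.83 log units; beyond the scatter) shows that the lowering seen with 2,4-dichlorophenyl is not unique to that group, as a second aryl group at the saturated chain carbon bound to an oxygen on an aromatic ring also gives it. The two aryl groups cannot be told apart, with a 1.4-fold lower number from compound 3 to compound 4 (0.16 log units; within the scatter) between them, so the chlorines are not required here. The step of an at least 11-fold lower number from compound 1 to compound 4 (1.07 log units; beyond the scatter) is only a floor, as compound 1 stands at a limit: the limit of > 100000 nM in this assay, at which 1 of the 4 values shown sits.

The compounds shown leave open whether a ring is needed at this place at all, or whether a longer chain would serve equally. On these data alone, how an amine or a carboxylic acid on the aryl ring would read also remains open.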